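The compounds below may be only part of what the source reports. "The series", "measured", "known", "first", "only" and "open" are said of these compounds alone.

The measured compounds:
compound 1, `O=C(Nc1ccc(Oc2ccnc3[nH]ccc23)cc1)c1nn(-c2ccc(Br)cc2)ccc1=O`, gives 4280 nM
compound 2, `O=C(Nc1ccc(Oc2ccnc3[nH]ccc23)c(F)c1)c1nn(-c2ccc(Br)cc2)ccc1=O`, gives 68000 nM
compound 3, `Cn1ccc2c(Oc3ccc(NC(=O)c4nn(-c5ccc(Cl)cc5)ccc4=O)cc3)ccnc21`, gives > 60000 nM

All three were tested in a functional assay on HepG2 cells (Homo sapiens) for cytotoxicity, read by MTT assay, with a stated time of 72 h; on this read-out lower numbers stand for stronger inhibition and higher numbers for weaker inhibition. Compound 1 and compound 2 differ only by fluoro in place of hydrogen on an aromatic carbon, and that change made a 16-fold higher number from compound 1 to compound 2 (1.20 log units; beyond the scatter). For compound 3 the result is a limit of the assay and not a number, namely > 60000 nM, one of the values that sit at the limit of > 60000 nM in this assay, at which 1 of the 3 values shown sits. How the core of compound 3 differs from the core of compound 1 is not broken down here.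

Compound 4, `Cn1ccc2c(Oc3ccc(NC(=O)c4nn(-c5ccc(Cl)cc5)ccc4=O)cc3F)ccnc21`, is not yet measured in this assay. It stands to compound 3 as compound 2 stands to compound 1, carrying (fluoro in place of hydrogen on an aromatic carbon), the same change at the same kind of place. Because the same change earlier gave a 16-fold higher number from compound 1 to compound 2 (1.20 log units; beyond the scatter), compound 4 is expected to land at or beyond the limit as well, with an estimated number of 120000 nM and a range from 40000 nM to 400000 nM. That estimate corresponds to an expected step that the limit leaves unreadable from compound 3 to compound 4.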

Compound 4, half-maximal inhibitory concentration: > 60000 nM
Compound 4: only a limit was reported; the forecaster's own chance of this, stated with the estimate: 85%; the middle value does not contradict the limit.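

In this assay compound 4 gives > 60000 nM, a limit and not a number. Compound 3 is likewise reported only as a limit, so no step between compound 3 and compound 4 can be read: the limit of > 60000 nM in this assay, at which 2 of the 4 values shown sit.

The compounds shown leave open whether fluoro in place of hydrogen on an aromatic carbon changes the true potency of compound 3.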